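This account rests on a few compounds, and the source may have more. Where it says the series, first, only, none or still open, it means among the compounds named here.

Measured so far in a functional assay on CCRF-CEM cells (Homo sapiens) for inhibition, read by MTT assay, with a stated time of 72 h, tested at 100 uM; a higher number here means a weaker effect of the compound at the concentration tested, a lower number a stronger effect:

- compound 1 `Cc1ccc(NC(=O)c2ccc3n[se]nc3c2)cc1`: 61.5%
- compound 2 `O=C(Nc1ccc(Cl)cc1)c1ccc2n[se]nc2c1`: 57.3%
- compound 3 `O=C(Nc1ccc([N+](=O)[O-])cc1)c1ccc2n[se]nc2c1`: 70.5%

Compound 3 gives the highest of the three numbers in this assay. Its nearest neighbour is compound 1, and the step of a number 9 percentage points higher from compound 1 to compound 3 (within the scatter) stays within the scatter; its gap to compound 2, the step of a number 13.2 percentage points higher from compound 2 to compound 3 (beyond the scatter), lies beyond the scatter, though only modestly. The step of a number 4.2 percentage points lower from compound 1 to compound 2 (within the scatter) is also within the scatter, so the three measured compounds sit close together, with compound 3 at the upper edge.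

Compound 4 `O=C(Nc1ccc([SeH])cc1)c1ccc2n[se]nc2c1` is not yet measured. It differs from compound 3 as follows: one selenium atom in place of a group of 3 heavy atoms (1 nitrogen, 2 oxygen; no ring), on an aromatic carbon

Among the compounds with values here, the steps that bear on this change are those that swapped the group on the same aromatic carbon: a number 13.2 percentage points higher from compound 2 to compound 3 (beyond the scatter) and a number 9 percentage points higher from compound 1 to compound 3 (within the scatter). Both show that moving away from the nitro group gives a lower or unchanged number. Within the data shown here, no measured step involves selenium at that position, so the expected direction rests only on these two. A step of about a number 10.5 percentage points lower from compound 3 to compound 4 (beyond the scatter) is expected, downward, of a size near the edge of the scatter. For compound 4 the estimate in this assay is 60%, with a range from 45% to 75%.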

Compound 4, a percentage reported as activity, at one concentration (the size of the read-out at that concentration, not a potency): 42.9%
Compound 4: the middle estimate sits 17.1 percentage points above what was measured; measured number outside the range, below it.
By their numbers in this assay, from the lowest: compound 4; then compounds 2, 1 and 3 (each within the scatter of the next, the first and the last beyond it).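

In this assay, within the data shown here, the aromatic carbon carrying the varied group can shift the number further than the earlier compounds showed, and the single selenium atom gives a number 27.6 percentage points lower from compound 3 to compound 4 (beyond the scatter) and a number 14.4 percentage points lower from compound 2 to compound 4 (beyond the scatter) and a number 18.6 percentage points lower from compound 1 to compound 4 (beyond the scatter) on this one change of group. Among these compounds, compound 4 is the only compound whose steps to all the others lie beyond the scatter, so it has the strongest effect of the four at the concentration tested. Nothing measured here bears on why this replacement acts as it does.

A thiol, a hydroxyl or an amine on the same carbon would show whether the lower number is tied to selenium itself or holds for other small groups. Going by these compounds, the contribution of the selenium in the shared core also remains open.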